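Methoxy substitution on the benzylamine of a purine series

The source may hold more compounds than are shown below. What is called first, only, known or untested is meant among the compounds shown, and "the series" means these compounds.

Measured so far in an ADME assay on K562 cells (Homo sapiens) for cytotoxicity, with a stated time of 72 h; a lower number here means a stronger inhibitor, a higher number a weaker inhibitor:
Compound 1 `Oc1ccc(CNc2ncnc3c2ncn3C2CCCCO2)cc1` gives a limit only, > 100000 nM.
Compound 2 `COc1cc(CNc2ncnc3c2ncn3C2CCCCO2)ccc1O` gives a limit only, > 100000 nM.
Compound 3 `COc1ccc(CNc2ncnc3c2ncn3C2CCCO2)cc1` gives a limit only, > 100000 nM.

Each of these readings is a limit of this assay and not a number. The change methoxy in place of hydrogen on an aromatic carbon gives a step that the two limits leave unreadable from compound 1 to compound 2, which cannot be read because of the limit of > 100000 nM in this assay, at which 3 of the 3 values shown sit. The difference between the cores of compound 1 and compound 3 is not broken down here.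

Compound 4 `COc1ccc(CNc2ncnc3c2ncn3C2CCCO2)cc1OC` is not yet measured. It differs from compound 3 by methoxy in place of hydrogen on an aromatic carbon, the same kind of change as from compound 1 to compound 2, though there the place was ortho to a hydroxy group (1 heavy atom) and here it is ortho to a methoxy group (2 heavy atoms). Going by the values given here, the step from compound 3 to compound 4 is expected to be about a step that the limit leaves unreadable from compound 3 to compound 4, resting only on the fact that every value so far sits at a limit because of the limit of > 100000 nM in this assay, at which 3 of the 3 values shown sit. Compound 4 is therefore estimated at 150000 nM in this assay, expected between 50000 nM and 500000 nM, most likely again reported only as a limit.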

Compound 4, half-maximal inhibitory concentration: > 100000 nM
Compound 4 ended at the assay's limit (the forecaster's own chance of this, stated with the estimate: 85%); the middle value is on the limit's open side.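

The step from compound 3 to compound 4 cannot be read, because both readings are limits and not numbers: the limit of > 100000 nM in this assay, at which 4 of the 4 values shown sit.

The compounds shown leave open whether any methoxy change in this series gives a measurable value in this assay.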